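The source may report more compounds than this note shows. Statements on the series, on what has been measured and on what is new or still open speak of the compounds shown alone.

Measured compounds:
- compound 1 `CC(C)c1c(C(=O)N2CCC[C@H](c3ccccc3)C2)nn(-c2ccc(F)cc2)c1OC[C@@H](O)C[C@@H](O)CC(=O)O`: 4.8 nM
- compound 2 `COc1ccccc1CNC(=O)c1nn(-c2ccc(F)cc2)c(OC[C@@H](O)C[C@@H](O)CC(=O)O)c1C(C)C`: 22 nM
- compound 3 `CC(C)c1c(C(=O)N(C)Cc2ccc(F)c(F)c2)nn(-c2ccc(F)cc2)c1OC[C@@H](O)C[C@@H](O)CC(=O)O`: 5.7 nM

All three were run in an assay on microsomes from liver for inhibition of 3-hydroxy-3-methylglutaryl-coenzyme A reductase (Rattus norvegicus); a higher number here means a weaker inhibitor, a lower number a stronger inhibitor. Compound 1 stands lowest of the three numbers; compound 3 is nearest, with a 1.2-fold higher number from compound 1 to compound 3 (0.07 log units; within the scatter), and compound 2 furthest, with a 4.6-fold higher number from compound 1 to compound 2 (0.66 log units; beyond the scatter).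

Compound 4 `CC(C)c1c(C(=O)N(C)Cc2ccc(F)cc2)nn(-c2ccc(F)cc2)c1OC[C@@H](O)C[C@@H](O)CC(=O)O` differs from compound 1 in one place: (4-fluorobenzyl)(methyl)amino in place of 3-phenylpiperidin-1-yl on a carbonyl carbon. The step that bears most on it is a 1.2-fold higher number from compound 1 to compound 3 (0.07 log units; within the scatter), as compound 3 carries the same methyl-bearing amide with a benzyl group differing only in fluorine count. The step of a 4.6-fold higher number from compound 1 to compound 2 (0.66 log units; beyond the scatter) concerns a secondary amide and is less comparable. No change beyond the scatter is therefore expected, so the estimated step is a 1.3-fold higher number from compound 1 to compound 4 (0.10 log units; within the scatter). Compound 4 is estimated at 6 nM, range 3 nM to 14 nM.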

Compound 4, half-maximal inhibitory concentration: 18 nM
Compound 4: middle estimate off by 3.0-fold (0.48 log units), on the low side; the whole stated range lies below it.
By their numbers in this assay, from the lowest: compounds 1 and 3 (each within the scatter of the next); then compounds 4 and 2 (each within the scatter of the next).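

In this assay, the benzyl group on the tertiary amide is sensitive to a single substituent: hydrogen in place of fluoro on an aromatic carbon gives a step beyond the scatter (a 3.2-fold higher number from compound 3 to compound 4 (0.50 log units; beyond the scatter)). The (4-fluorobenzyl)(methyl)amino group therefore does not share the near match of the difluorinated amide to 3-phenylpiperidin-1-yl (a 3.8-fold higher number from compound 1 to compound 4 (0.57 log units; beyond the scatter)). It instead stands level with the (2-methoxybenzyl)amino amide (a 1.2-fold lower number from compound 2 to compound 4 (0.09 log units; within the scatter)). No evidence at hand accounts for this step.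

As far as these compounds go, whether chloro or trifluoromethyl in place of that fluoro would keep the lower number remains open.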